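A Dimethylamino Swap at the Limit of the Assay

The source may hold more compounds than are shown below. What is called first, only, known or untested is meant among the compounds shown, and "the series" means these compounds.

Of the compounds shown here, three sharing one core have been measured in a functional assay on HT-29 cells (Homo sapiens) for inhibition; a lower number here means a stronger inhibitor, a higher number a weaker inhibitor. Compound 1 `COc1ccc(/C=C/c2ccc3ccccc3c2)cc1`, carrying methoxy, gives > 5000 nM, which is a limit and not a number. Compound 2 `Cc1ccc(/C=C/c2ccc3ccccc3c2)cc1`, carrying methyl, gives > 5000 nM, again a limit. Compound 3 `FC(F)(F)c1ccc(/C=C/c2ccc3ccccc3c2)cc1`, carrying trifluoromethyl, gives > 5000 nM, also a limit. Compound 3 therefore has no exact value and stands level with the other two: the limit of > 5000 nM in this assay, at which 3 of the 3 values shown sit.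

Compound 4 `CN(C)c1ccc(/C=C/c2ccc3ccccc3c2)cc1` has dimethylamino in place of trifluoromethyl on an aromatic carbon. The measured steps that bear on this swap are a step that the two limits leave unreadable from compound 1 to compound 2, a step that the two limits leave unreadable from compound 1 to compound 3 and a step that the two limits leave unreadable from compound 2 to compound 3, and they offer no size to carry over, so no large change is expected. The estimated step is a step that the limit leaves unreadable from compound 3 to compound 4, with no firm direction. Compound 4 is expected at about 6000 nM, within an estimated range of 1500 nM to 20000 nM.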

Compound 4, half-maximal inhibitory concentration: 3660 nM
Compound 4: middle estimate off by 1.6-fold (0.21 log units), on the high side; the range from low to high includes it.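

Among the four groups at this position, dimethylamino alone gives an exact number in this assay, while the others leave only a limit: the limit of > 5000 nM in this assay, at which 3 of the 4 values shown sit.

Against trifluoromethyl, the swap reads as an at least 1.3-fold lower number from compound 3 to compound 4 (0.13 log units; that floor lies within the scatter); against methyl, as an at least 1.3-fold lower number from compound 2 to compound 4 (0.13 log units; that floor lies within the scatter); and against methoxy, as an at least 1.3-fold lower number from compound 1 to compound 4 (0.13 log units; that floor lies within the scatter). Each of these is only a floor lying within the scatter, so compound 4 cannot yet be called a stronger inhibitor than the others, but it does give this position its first exact reference value.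

The compounds shown leave open how a primary amine, a diethylamino group or a carboxylic acid would read at this place. From the compounds shown here alone, the steps among compound 1, compound 2 and compound 3 cannot be read, so how these three groups rank remains open.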